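This account rests on a few compounds, and the source may have more. Where it says the series, first, only, none or still open, it means among the compounds named here.

Compound 1 `N#C/C(=C\c1ccc([N+](=O)[O-])cc1)C(=O)c1c[nH]c2ccccc12` gives 46000 nM in a functional assay on MIA cells (Homo sapiens) for inhibition, read by MTT assay, with a stated time of 72 h; a higher number here means a weaker inhibitor of growth, a lower number a stronger inhibitor of growth. Compound 2 `COc1ccc(CNC(=O)/C(C#N)=C/c2ccc(Cl)o2)cc1` gives 15000 nM. Compound 3 `COc1ccc(CNC(=O)/C(C#N)=C/c2ccc(-c3ccccc3)o2)cc1` reaches only the limit of this assay, > 100000 nM.

Among the two plain numbers compound 2 stands lowest, and compound 1 gives the higher number, a gap beyond the scatter. Compound 3 sits at the limit (the limit of > 100000 nM in this assay, at which 1 of the 3 values shown sits), so its number is not known. Compound 4 `COc1ccc(CNC(=O)/C(C#N)=C/c2ccoc2)cc1` differs from compound 2 in one place: furan-3-yl in place of 5-chlorofuran-2-yl on a double-bonded chain carbon bound to a double-bonded chain carbon. Among the measured compounds shown here, no measured pair carries this exact change. For the measured compounds named here, the only measured step at the same furan ring is an at least 6.6-fold higher number from compound 2 to compound 3 (0.82 log units; beyond the scatter), in which a larger group in place of the chloro sent the number up beyond the scatter. The change to compound 4 removes the chloro and shifts the point of attachment of the ring, a smaller alteration than adding a phenyl, so a step of the same size is not expected, but the measured step shows that this ring is sensitive to what sits on it. The step from compound 2 to compound 4 is therefore expected to be a 2.0-fold higher number from compound 2 to compound 4 (0.30 log units; within the scatter). Compound 4 is estimated at 30000 nM, within a range from 10000 nM to 100000 nM.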

Compound 4, concentration for 50% growth inhibition: 8000 nM
Beside the measured number, compound 4's estimate is 3.8-fold (0.57 log units) above it, and the stated range ends above it.
By their numbers in this assay, from the lowest: compounds 4 and 2 (each within the scatter of the next); then compound 1. At a limit, above all of these: compound 3.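

In this assay, the change to furan-3-yl is a 1.9-fold lower number from compound 2 to compound 4 (0.27 log units; within the scatter), so on this double-bonded chain carbon the 5-chlorofuran-2-yl can give way to a ring without the chlorine, attached through another ring carbon, and the number stays within the scatter. Among the compounds shown here, the earlier compounds showed only one step at this ring, an at least 6.6-fold higher number from compound 2 to compound 3 (0.82 log units; beyond the scatter), and the present result shows that such a rise in the number holds for phenyl in place of chloro but does not extend to every change at this position. The compounds shown offer nothing that accounts for either step.

Compound 4 differs from compound 2 both in the loss of the chloro and in the point of attachment of the ring, so the part each of these plays in the step cannot be separated from the other. Also open, on these data alone, is what would follow if an amine, a carboxylic acid or a methyl group stood on the furan ring in place of the chloro or the phenyl.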